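The compounds below may be only part of what the source reports. "The series", "measured", "known", "first", "only" and "open" are said of these compounds alone.

Compound 1, `COC(=O)[C@H](NC(=O)Cn1cc(C2=C(c3c[nH]c4ccccc34)C(=O)N(C)C2=O)c2ccccc21)C(C)C`, gives 30600 nM in a functional assay on A549 cells (Homo sapiens) for cytotoxicity, read by MTT assay, with a stated time of 24 h; on this read-out higher numbers stand for weaker inhibition and lower numbers for stronger inhibition.
Compound 2, `COC(=O)[C@@H](CO)NC(=O)Cn1cc(C2=C(c3c[nH]c4ccccc34)C(=O)N(C)C2=O)c2ccccc21`, gives 37900 nM in this assay.
Compound 3, `COC(=O)CC[C@@H](NC(=O)Cn1cc(C2=C(c3c[nH]c4ccccc34)C(=O)N(C)C2=O)c2ccccc21)C(=O)OC`, gives 73700 nM in this assay.

All three share the same core and differ only in the group attached to the chain carbon that carries the methyl ester. Compound 3 gives the highest of the three numbers: its step from compound 1, a 2.4-fold higher number from compound 1 to compound 3 (0.38 log units; beyond the scatter), lies beyond the scatter, while its step from compound 2, a 1.9-fold higher number from compound 2 to compound 3 (0.29 log units; within the scatter), does not.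

Compound 4, `COC(=O)[C@@H](CC(C)C)NC(=O)Cn1cc(C2=C(c3c[nH]c4ccccc34)C(=O)N(C)C2=O)c2ccccc21`, is the next step. The change from compound 3 is isopropyl in place of (methoxycarbonyl)methyl on a saturated chain carbon, two bonds along the chain from an amide-type nitrogen and a carbonyl carbon. It roughly reverses the change seen in a 2.4-fold higher number from compound 1 to compound 3 (0.38 log units; beyond the scatter), only cut one bond further out, where an ester-bearing chain gave way to an isopropyl group and the number rose modestly. The expectation is therefore a modest move in the opposite direction in this assay, that is a 2.2-fold lower number from compound 3 to compound 4 (0.35 log units; beyond the scatter), a lower number than compound 3, though perhaps not beyond the scatter. Compound 4 is estimated at 33000 nM, with a range of 15000 nM to 75000 nM.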

Compound 4, half-maximal inhibitory concentration: > 100000 nM
Compound 4 gave a limit, no number; the forecaster's own chance of this, stated with the estimate: 10%; middle value at least 3.0-fold (0.48 log units) away from the limit.
By their numbers in this assay, from the lowest: compounds 1, 2 and 3 (each within the scatter of the next, the first and the last beyond it). At a limit, above all of these: compound 4.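

Compound 4 gives a limit and not a number: the limit of > 100000 nM in this assay, at which 1 of the 4 values shown sits. Among the compounds shown here, at this chain carbon, a small change among carbon-only groups counts: isobutyl in place of isopropyl gives an at least 3.2-fold higher number from compound 1 to compound 4 (0.51 log units; beyond the scatter), the largest step so far, so the carbon-only group of compound 1 does not stand for carbon-only groups in general here. Isopropyl in place of hydroxy, two bonds along the chain, gives an at least 2.6-fold higher number from compound 2 to compound 4 (0.42 log units; beyond the scatter), while isopropyl in place of (methoxycarbonyl)methyl gives an at least 1.3-fold higher number from compound 3 to compound 4 (0.13 log units; that floor lies within the scatter), a floor that leaves open whether compound 4 truly parts from compound 3.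

On these data alone, how far compound 4 lies past its limit stays unknown, so the full size of these steps cannot be read. Also open, as far as these compounds go, is how an amine, a carboxylic acid or a longer unbranched chain would read on this carbon.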